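Bromoethenyl for ethyl: cytotoxicity outlook for compound 3

A few compounds are considered here, and "the series" means these few. Any claim that something is new, unique, unknown or untested is made for them only; others in the source may bear on it.

The shared core is seen in compound 1 `O=c1ccn(C2COC(CO)C(O)C2)c(=O)[nH]1`. In a functional assay on E6SM cells (Homo sapiens) for cytotoxicity, read by microscopy (on this read-out higher numbers stand for lower toxicity in this test and lower numbers for higher toxicity in this test), compound 1 gives only a limit of the assay, > 400 ug/mL. Compound 2 `CCc1cn(C2COC(CO)C(O)C2)c(=O)[nH]c1=O` carries ethyl in place of hydrogen on an aromatic carbon. In this assay compound 2 likewise gives only a limit, > 400 ug/mL. Going by the values given here, the step that the two limits leave unreadable from compound 1 to compound 2 is unreadable, both of its ends being limits; the one fixed point in the numbers so far is the limit of > 400 ug/mL in this assay, at which 2 of the 2 values shown sit.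

Compound 3 `O=c1[nH]c(=O)n(C2COC(CO)C(O)C2)cc1/C=C/Br` differs from compound 2 by 2-bromoethenyl in place of ethyl on an aromatic carbon. Among the compounds with values here, no measured step of readable size bears on this change: the only step available is the unreadable one from compound 1 to compound 2, and both values shown sit at the same limit. Nothing in the numbers therefore points to a shift in either direction, and the step of a number no higher from compound 2 to compound 3 (the limit leaves the size open) is expected to be none beyond the scatter, most likely ending again at the limit. In this assay compound 3 is estimated at 400 ug/mL, with a range from 100 ug/mL to 400 ug/mL.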

Compound 3, minimum cytotoxic concentration: > 400 ug/mL
Compound 3: only a limit was reported; the forecaster's own chance of this, stated with the estimate: 70%; the middle value sits exactly at the limit.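

In this assay compound 3 gives > 400 ug/mL, which is a limit of the assay. No step among compound 1, compound 2 and compound 3 can be read: the limit of > 400 ug/mL in this assay, at which 3 of the 3 values shown sit.

The compounds shown leave open whether any group on this aromatic carbon shifts the read-out at all.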